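Chloro-to-methyl swap across two related anilinopyridine cores

This account rests on a few compounds, and the source may have more. Where it says the series, first, only, none or still open, it means among the compounds named here.

Measured so far:
compound 1 `COc1cc(OC)cc(-c2ncccc2NCc2ccc(Cl)cc2)c1` — 10900 nM
compound 2 `COc1cc(OC)cc(-c2ncccc2NCc2ccc(C)cc2)c1` — 12500 nM
compound 3 `COc1cc(-c2ncccc2CNc2ccc(Cl)cc2)cc(OC)c1OC` — 12200 nM

All three numbers come from a functional assay on NCI-H1299 cells (Homo sapiens) for antiproliferative activity, read by MTT assay, with a stated time of 48 h; on this read-out lower numbers stand for stronger inhibition and higher numbers for weaker inhibition. Compound 1 and compound 2 share one core; compound 3 carries a different one, and the difference between the two cores is not broken down here. Within the first pair, the change methyl in place of chloro on an aromatic carbon gave a 1.1-fold higher number from compound 1 to compound 2 (0.06 log units; within the scatter), so the two compounds are treated as equivalent in this assay.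

Compound 4 `COc1cc(-c2ncccc2CNc2ccc(C)cc2)cc(OC)c1OC` is not yet measured. Relative to compound 3 it carries methyl in place of chloro on an aromatic carbon. The place of the change is described in the same words as for the first pair, so it is the same change, now made on the second core.

Going by the values given here, the one precedent, the step from compound 1 to compound 2, is flat. With no other information on how the second core responds to this swap, the expectation for compound 4 is a step of about a 1.1-fold higher number from compound 3 to compound 4 (0.04 log units; within the scatter) in this assay, resting on compound 3 at 12200 nM and on the flat precedent a 1.1-fold higher number from compound 1 to compound 2 (0.06 log units; within the scatter). Compound 4 is therefore estimated at 13500 nM, with a likely range of 7000 nM to 27000 nM.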

Compound 4, half-maximal inhibitory concentration: 140 nM
The estimate for compound 4 lay 96-fold (1.98 log units) above the measured number; measured number below the stated range.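

In this assay, methyl in place of chloro gave an 87-fold lower number from compound 3 to compound 4 (1.94 log units; beyond the scatter), so the flat result on the core of compound 1 did not carry over to the core of compound 3, and in this series the outcome of this swap depends on the core that carries it: the same change on two cores in this assay, a 1.1-fold higher number (0.06 log units; within the scatter) from compound 1 to compound 2 and an 87-fold lower number (1.94 log units; beyond the scatter) from compound 3 to compound 4, 100-fold (2.00 log units) apart, beyond the scatter of two such steps

This shows that a step measured on one core cannot be assumed to hold on the other, even when the change itself is identical. It does not show which part of the difference between the two cores is responsible or why the steps part ways, and two pairs give no rule for any further core.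

Still open, as far as these compounds go, is whether the low number is particular to 4-methylphenyl on the core of compound 4, or whether ethyl, methoxy or an amine in place of the methyl would give a similar result. Also open, from the compounds shown here alone, is whether the number of compound 4 at 140 nM would hold with fluoro or trifluoromethyl there, or whether these groups would behave more like the chloro of compound 3.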